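A few compounds are considered here, and "the series" means these few. Any claim that something is new, unique, unknown or untested is made for them only; others in the source may bear on it.

Values in a functional assay on the whole organism with Mus musculus as the target (on this read-out higher numbers stand for an effect only at larger amounts of compound and lower numbers for an effect already at smaller amounts), for the compounds measured so far
Compound 1 `C[C@@H](NCc1ccc(OCc2ccc(F)cc2)cc1)C(N)=O` gives 132 mg/kg
Compound 2 `C[C@@H](NCc1ccc(OCc2ccccn2)cc1)C(N)=O` gives 172 mg/kg
Compound 3 `C[C@@H](NCc1ccc(OCc2cccs2)cc1)C(N)=O` gives 61.6 mg/kg

Compound 3 stands lowest of the three, with its steps to both others beyond the scatter. For the measured compounds named here, compound 4 `C[C@@H](NCc1ccc(OCC2CCCCC2)cc1)C(N)=O` differs from compound 3 by cyclohexyl in place of thiophen-2-yl on a saturated chain carbon bound to an oxygen on an aromatic ring and no measured compound carries a non-aromatic ring at this place. Going by the values given here, three measured steps bear on it, each exchanging the group at this place: a 1.3-fold higher number from compound 1 to compound 2 (0.11 log units; within the scatter) stays within the scatter, while a 2.1-fold lower number from compound 1 to compound 3 (0.33 log units; beyond the scatter) and a 2.8-fold lower number from compound 2 to compound 3 (0.45 log units; beyond the scatter) are modest. Since compound 3 at 61.6 mg/kg is the lowest, a modest rise of similar size is expected in this assay on leaving the thiophen-2-yl. The expected step is a 1.6-fold higher number from compound 3 to compound 4 (0.21 log units; within the scatter) by this estimate. The estimated value for compound 4 is 100 mg/kg within an expected range from 40 mg/kg to 250 mg/kg.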

Compound 4, dose for half-maximal effect: 131 mg/kg
Compound 4: middle estimate off by 1.3-fold (0.12 log units), on the low side; measured number inside the range.
By their numbers in this assay, from the lowest: compound 3; then compounds 4, 1 and 2 (each within the scatter of the next).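

In this assay, an aromatic ring is not needed at this place: a 1.0-fold lower number from compound 1 to compound 4 (0.00 log units; within the scatter) and a 1.3-fold lower number from compound 2 to compound 4 (0.12 log units; within the scatter) both stay within the scatter, so cyclohexyl cannot be told apart from 4-fluorophenyl or pyridin-2-yl. Among these four compounds only thiophen-2-yl stands apart, with a 2.1-fold higher number from compound 3 to compound 4 (0.33 log units; beyond the scatter) on going to the non-aromatic ring. Going by these compounds, how an amine, a carboxylic acid or a longer chain would read at this place in this assay remains open. Nothing given here explains why compound 3 stands apart.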